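This account rests on a few compounds, and the source may have more. Where it says the series, first, only, none or still open, it means among the compounds named here.

Measured in a functional assay on COLO 205 cells (Homo sapiens) for inhibition, read by sulforhodamine B assay, with a stated time of 48 h, tested at 50 uM; on this read-out higher numbers stand for more inhibition of growth at the one concentration tested and lower numbers for less inhibition of growth:
- compound 1 `COc1cccc(/C=C/C(=O)/C=C/c2ccc(OCc3cn(CCCCOc4cc(=O)oc5ccccc45)nn3)c(OC)c2)c1`: 46%
- compound 2 `COc1cc(/C=C/C(=O)/C=C/c2ccccc2)ccc1OCc1cn(CCCCOc2cc(=O)oc3ccccc23)nn1`: 31%
- compound 3 `COc1cc(/C=C/C(=O)/C=C/c2ccco2)ccc1OCc1cn(CCCCOc2cc(=O)oc3ccccc23)nn1`: 43%

In this set, compound 3 lies within the scatter of compound 1, and compound 2 lies clearly lower. Compound 4 `COc1cc(/C=C/C(=O)/C=C/c2cccs2)ccc1OCc1cn(CCCCOc2cc(=O)oc3ccccc23)nn1` carries thiophen-2-yl in place of furan-2-yl on a double-bonded chain carbon bound to a double-bonded chain carbon. Two measured steps change this same place: a number 12 percentage points higher from compound 2 to compound 3 (beyond the scatter), and a number 3 percentage points lower from compound 1 to compound 3 (within the scatter). Within the data shown here, neither of them introduces thiophen-2-yl, so the data offer no direct precedent. The incoming group has the same counted features apart from its hetero atom, so the expected step is a number 3 percentage points lower from compound 3 to compound 4 (within the scatter), none beyond the scatter. The estimate for compound 4 is 40%, with an expected range of 29% to 52%.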

Compound 4, percent growth inhibition at one concentration: 40%
Compound 4: the middle estimate sits on the measured number at the digits printed, and the stated range covers the measured number.
By their numbers in this assay, from the lowest: compounds 2, 4, 3 and 1 (each within the scatter of the next, the first and the last beyond it).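

In this assay the change from furan-2-yl to thiophen-2-yl gives a number 3 percentage points lower from compound 3 to compound 4 (within the scatter) and so shows that oxygen or sulfur as the hetero atom of this five-membered aromatic ring makes no readable difference at this place. Thiophen-2-yl also stays within the scatter of phenyl, with a number 9 percentage points higher from compound 2 to compound 4 (within the scatter) as its step, whereas furan-2-yl shows a number 12 percentage points higher from compound 2 to compound 3 (beyond the scatter) and lies beyond it. Against 3-methoxyphenyl, the change gives a number 6 percentage points lower from compound 1 to compound 4 (within the scatter) and again stays within the scatter. No available evidence explains these readings. The compounds shown leave open how pyridin-2-yl, or a phenyl carrying a carboxylic acid, would read at this place.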